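Bromo in Place of Methoxy: What Compound 4 May Give

A few compounds are considered here, and "the series" means these few. Any claim that something is new, unique, unknown or untested is made for them only; others in the source may bear on it.

In a functional assay on MCF7 cells (Homo sapiens) for antiproliferative activity, read by MTT assay (a higher number here means a weaker inhibitor, a lower number a stronger inhibitor), compound 1 `COc1ccc(-c2ccnc(Nc3cccc(OC)c3)n2)cc1` gives 3450 nM, and compound 3 `COc1ccc(-c2ccnc(Nc3ccc(Cl)cc3)n2)cc1` gives 810 nM; the difference between these two cores is not broken down here. Compound 2 `Clc1ccc(Nc2nccc(-c3ccc(Br)cc3)n2)cc1` differs from compound 3 by bromo in place of methoxy on an aromatic carbon, and in this assay compound 2 gives 4180 nM, a step of a 5.2-fold higher number from compound 3 to compound 2 (0.71 log units; beyond the scatter). Compound 4 `COc1cccc(Nc2nccc(-c3ccc(Br)cc3)n2)c1` has not yet been measured; it differs from compound 1 by bromo in place of methoxy on an aromatic carbon, the same change at the same place. Because the step of a 5.2-fold higher number from compound 3 to compound 2 (0.71 log units; beyond the scatter) lies beyond the scatter, a step of similar size and direction is expected from compound 1, namely a 4.1-fold higher number from compound 1 to compound 4 (0.61 log units; beyond the scatter). Compound 4 is therefore estimated at 14000 nM, with an expected range from 5000 nM to 40000 nM. The change occurs only once among the measured compounds, and the range is kept wide.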

Compound 4, half-maximal inhibitory concentration: 278000 nM
For compound 4 the middle estimate is 20-fold (1.30 log units) below the measured one; measured number outside the range, above it.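

In this assay, bromo in place of methoxy on an aromatic carbon gives an 81-fold higher number from compound 1 to compound 4 (1.91 log units; beyond the scatter) and so runs in the same direction as on the other core, but the size of the step does not carry over: the same change on two cores in this assay, a 5.2-fold higher number (0.71 log units; beyond the scatter) from compound 3 to compound 2 and an 81-fold higher number (1.91 log units; beyond the scatter) from compound 1 to compound 4, 16-fold (1.19 log units) apart, beyond the scatter of two such steps.

The direction therefore holds across both cores shown, while the size of the step on one core gives a poor guide to its size on the other. Two cores cannot show what sets that size, or how the change would behave on a third core.

The compounds shown leave open how the activity responds when the methoxy gives way to other groups, such as an amine, a nitrile or a carboxylic acid. They also leave open whether either core would tolerate such groups better than bromo.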